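From a Naphthalenylmethyl Arm to a Chlorobenzyl Group

The source may report more compounds than this note shows. Statements on the series, on what has been measured and on what is new or still open speak of the compounds shown alone.

Compound 1 `Cc1cc(-c2ccccc2)n(/C(N)=N/S(=O)(=O)c2cc(C)c(Cl)cc2SCc2cccc3ccccc23)n1` gives 7000 nM in a functional assay on HCT-116 cells (Homo sapiens) for cytotoxicity, read by MTT assay, with a stated time of 72 h; a lower number here means a stronger inhibitor, a higher number a weaker inhibitor. Compound 2 `Cc1cc(S(=O)(=O)/N=C(\N)n2nccc2-c2ccccc2)c(SCc2cccc(Cl)c2)cc1Cl` gives 7000 nM in this assay, and compound 3 `Cc1cc(S(=O)(=O)/N=C(\N)n2nccc2-c2ccccc2)c(SCc2cccc3ccccc23)cc1Cl` gives 7000 nM, so compound 1 sits level with both. The step of no change at the digits printed from compound 1 to compound 3 (within the scatter) and the step of no change at the digits printed from compound 2 to compound 3 (within the scatter) each stayed within the scatter. Compound 4 `Cc1cc(-c2ccccc2)n(/C(N)=N/S(=O)(=O)c2cc(C)c(Cl)cc2SCc2ccc(Cl)cc2)n1` differs from compound 1 by 4-chlorophenyl in place of naphthalen-1-yl on a saturated chain carbon bound to a sulfur. The step from compound 2 to compound 3 bears most directly on this change, since it also exchanges a chlorophenyl group and naphthalen-1-yl on a saturated chain carbon bound to a sulfur, and it showed no movement beyond the scatter. On that basis the expected step is no change at the digits printed from compound 1 to compound 4 (within the scatter). Compound 4 is estimated at 7000 nM, ranging from 3500 nM to 14000 nM.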

Compound 4, half-maximal inhibitory concentration: 7000 nM
For compound 4 middle estimate and measured number coincide at the digits printed, within the range that was stated.
By their numbers in this assay, from the lowest: compounds 1, 2, 3 and 4 (each within the scatter of the next).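

In this assay there is no change at the digits printed from compound 1 to compound 4 (within the scatter) when 4-chlorophenyl replaces naphthalen-1-yl, so on the core of compound 1 this place accepts one chlorine-bearing aromatic ring as readily as two aromatic rings. Nothing measured here accounts for this flat result.

All the groups shown at this place are aromatic, so they leave open whether any change here can shift the number at all. A group such as an amine or a carboxylic acid on the saturated chain carbon bound to a sulfur remains an open case.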